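The compounds below may be only part of what the source reports. "The series", "measured", "known", "first", "only" and "open" are said of these compounds alone.

Working notes on a small set of oxime ethers sharing one core. Compound 1 `Cc1nnsc1CO/N=C/c1c(C)nn(C)c1Oc1ccc(OC(F)(F)F)cc1` gives 11500 nM in a functional assay on SGC-7901 cells (Homo sapiens) for inhibition, read by MTT assay, with a stated time of 48 h; on this read-out lower numbers stand for stronger inhibition and higher numbers for weaker inhibition. Compound 3 `CCc1nnsc1CO/N=C/c1c(C)nn(C)c1Oc1ccc(OC(F)(F)F)cc1` differs from compound 1 by methyl in place of hydrogen on a saturated chain carbon bound to an aromatic carbon; in this assay compound 3 gives 13600 nM, and the step is a 1.2-fold higher number from compound 1 to compound 3 (0.07 log units; within the scatter). Compound 2 `CCc1nnsc1CO/N=C/c1c(C)nn(C)c1Oc1ccccc1Cl` carries a different core; the difference between the two cores is not broken down here. In this assay compound 2 gives 15800 nM, within the scatter of compound 1 and compound 3.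

Compound 4 `CCCc1nnsc1CO/N=C/c1c(C)nn(C)c1Oc1ccccc1Cl` is not yet measured and differs from compound 2 by methyl in place of hydrogen on a saturated chain carbon, two bonds along the chain from an aromatic carbon. This is the same kind of change as that from compound 1 to compound 3, though the place differs: there the saturated chain carbon is bound to an aromatic carbon, here it is two bonds along the chain from an aromatic carbon. For compound 4 the expected step is a 1.1-fold higher number from compound 2 to compound 4 (0.03 log units; within the scatter), resting on the step of a 1.2-fold higher number from compound 1 to compound 3 (0.07 log units; within the scatter), which stayed within the scatter. Compound 4 is thus estimated at 17000 nM in this assay, expected between 8000 nM and 36000 nM.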

Compound 4, half-maximal inhibitory concentration: 17600 nM
Estimate against measurement, compound 4: 1.0-fold (0.02 log units) below; the measured number falls inside the stated range.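

Going from ethyl to propyl in this assay gives a 1.1-fold higher number from compound 2 to compound 4 (0.05 log units; within the scatter). Set beside the methyl to ethyl step on the other core, this step cannot be told apart from the earlier one: the same change on two cores in this assay, a 1.2-fold higher number (0.07 log units; within the scatter) from compound 1 to compound 3 and a 1.1-fold higher number (0.05 log units; within the scatter) from compound 2 to compound 4, 1.1-fold (0.03 log units) apart, within the scatter of two such steps. This shows that the added methyl stays within the scatter on both cores; it does not show a real effect of the methyl on either core, and the two steps differ in place as well as in core, which leaves no general rule for other cores.

The compounds shown leave open whether a chain longer than propyl, a branched chain such as isopropyl, or a chain ending in an amine or a carboxylic acid would move the number in this assay beyond the scatter.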